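The compounds below may be only part of what the source reports. "The series", "measured", "known", "first", "only" and "open" are said of these compounds alone.

Of the compounds shown here, two built on a shared core have been measured in an assay for inhibition of Polyunsaturated fatty acid 5-lipoxygenase (Homo sapiens), read by spectrophotometry, tested at 10 uM; a lower number here means less inhibition, a higher number more inhibition at the concentration tested (going by the name of the read-out). Compound 1 `O=C(c1ccccc1)c1sc(N2CCCCC2)nc1-c1ccccc1` gives 85.2% in this assay. Compound 2 `O=C(c1ccccc1)c1sc(N2CCN(c3ccccc3)CC2)nc1-c1ccccc1` gives 38.3% in this assay, the lower of the two numbers, and compound 1 sits above it by a gap that is beyond the usual scatter. Within the data shown here, no single-point step between these two is counted, so only their two values are stated here.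

Compound 3 `O=C(c1ccccc1)c1sc(N2CCN(c3ccccc3)CC2)nc1-c1ccc([N+](=O)[O-])cc1` has not yet been measured. It differs from compound 2 in one place: nitro in place of hydrogen on an aromatic carbon. Among the measured compounds shown here, nothing among the measured compounds shows what a nitro group at this place does. Compounds 1 and 2 differ from each other elsewhere. The expectation therefore rests on compound 2 alone, whose value of 38.3% is the only anchor. The step of a number 1.7 percentage points higher from compound 2 to compound 3 (within the scatter) is expected to be small, in either direction, and most likely not beyond the scatter. Compound 3 is expected to give about 40% in this assay, within a range from 15% to 68%.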

Compound 3, a percentage reported as inhibition, at one concentration (the size of the read-out at that concentration, not a potency): 67.8%
Beside the measured number, compound 3's estimate is 27.8 percentage points below it, and the stated range covers the measured number.
By their numbers in this assay, from the lowest: compound 2; then compound 3; then compound 1.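

In this assay, the change from phenyl to 4-nitrophenyl gives a number 29.5 percentage points higher from compound 2 to compound 3 (beyond the scatter), the first sign that this aromatic carbon, para to a large group, is not indifferent to substitution. The earlier pair differed elsewhere and said nothing about this ring, whereas this step isolates a single change: a hydrogen atom gives way to a nitro group, and inhibition at the tested concentration rises beyond the scatter. No supporting evidence bears on what lies behind this rise, so the step stands as an observation only.

The compounds shown leave open whether the rise is particular to nitro or would also follow from another group on the same carbon, such as an amine, a carboxylic acid, a methoxy group or a chlorine atom. They also leave open whether a nitro group in the same place would shift the value of compound 1 in the same direction, and whether the same group on another carbon of this ring would give a step of similar size.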